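Swapping a chlorophenyl for a methylbenzoxazole on the core

This account rests on a few compounds, and the source may have more. Where it says the series, first, only, none or still open, it means among the compounds named here.

Among the measured compounds shown here, in an assay on CHO cells for displacement of a labelled ligand from prostaglandin E2 receptor EP1 subtype (Mus musculus), read by scintillation counting, with a stated time of 20 min (on this read-out higher numbers stand for weaker inhibition and lower numbers for stronger inhibition), compound 2 `O=C(O)c1csc(SCCN2C(=O)CC[C@@H]2/C=C/[C@@H](O)Cc2cccc(-c3ccc(Cl)cc3)c2)n1` gives 6300 nM, the only actual number among the two values shown. Compound 1 `O=C(O)CCCSCCN1C(=O)CC[C@@H]1/C=C/[C@@H](O)Cc1cccc(-c2nc3ccccc3s2)c1` reaches only a limit of this assay, > 10000 nM, and not a number. Compound 3 `Cc1cccc2oc(-c3cccc(C[C@H](O)/C=C/[C@H]4CCC(=O)N4CCSc4nc(C(=O)O)cs4)c3)nc12` differs from compound 2 in one place: 4-methyl-1,3-benzoxazol-2-yl in place of 4-chlorophenyl on an aromatic carbon. For the measured compounds named here, no pair of measured compounds separated by this change exists, so its effect is unknown. The step is expected to be a 1.3-fold lower number from compound 2 to compound 3 (0.10 log units; within the scatter), not beyond the usual scatter. Compound 3 is therefore estimated at 5000 nM, with a range from 1500 nM to 20000 nM.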

Compound 3, inhibition constant: 7700 nM
For compound 3 the middle estimate is 1.5-fold (0.19 log units) below the measured one; the measured number falls inside the stated range.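

Putting 4-methyl-1,3-benzoxazol-2-yl in place of 4-chlorophenyl on this aromatic carbon gives a 1.2-fold higher number from compound 2 to compound 3 (0.09 log units; within the scatter). A larger group with a second aromatic ring and hydrogen-bond acceptors therefore reads the same here as 4-chlorophenyl in this assay. Compound 1 differs from both in more than one place and stands at a limit, not a number, so no step to it can be read: the limit of > 10000 nM in this assay, at which 1 of the 3 values shown sits.

Going by these compounds, whether an amine or a carboxylic acid on this aromatic carbon would move the number stays open.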